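Ethoxy added to the anilide of compound 2

A few compounds are considered here, and "the series" means these few. Any claim that something is new, unique, unknown or untested is made for them only; others in the source may bear on it.

Compound 1 `CCOc1ccc(NC(=O)c2cn(-c3ccccc3)nc2-c2ccccc2)cc1` gives 620 nM in a functional assay on HCT-116 cells (Homo sapiens) for cytotoxicity, read by MTT assay, with a stated time of 48 h; on this read-out lower numbers stand for stronger inhibition and higher numbers for weaker inhibition.
Compound 2 `O=C(Nc1ccccc1)c1cn(-c2ccccc2)nc1-c1ccc([N+](=O)[O-])cc1` gives 2010 nM in this assay.

Of the two measured compounds, compound 2 has the higher number in this assay; the number of compound 1 is lower, and the gap between them lies beyond the scatter. Among the compounds with values here, the two compounds differ in more than one place, so no single step connects them.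

Compound 3 `CCOc1ccc(NC(=O)c2cn(-c3ccccc3)nc2-c2ccc([N+](=O)[O-])cc2)cc1` has not yet been measured. It keeps the core of compound 2 and differs from it in one place only: ethoxy in place of hydrogen on an aromatic carbon. Within the data shown here, compound 1, the only other measured compound, carries this ethoxy group, but it lacks the nitro group of compound 2, so the data give no isolated measure of what the ethoxy group alone does.

For compound 3 a small step to a lower number, if any, is expected in this assay, of the size a 1.7-fold lower number from compound 2 to compound 3 (0.22 log units; within the scatter). Compound 3 is therefore estimated at 1200 nM, with a range from 400 nM to 3500 nM.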

Compound 3, half-maximal inhibitory concentration: 390 nM
Compound 3: the middle estimate sits 3.1-fold (0.49 log units) above what was measured; measured number below the stated range.
By their numbers in this assay, from the lowest: compounds 3 and 1 (each within the scatter of the next); then compound 2.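

In this assay, within the data shown here, the change from phenyl to 4-ethoxyphenyl gives a 5.2-fold lower number from compound 2 to compound 3 (0.71 log units; beyond the scatter), the first reading of the ethoxy group on its own, and this step lies beyond the scatter. With ethoxy in place, adding the nitro group gives a 1.6-fold lower number from compound 1 to compound 3 (0.20 log units; within the scatter), which lies within the scatter, so this pair shows no measurable difference from adding that group. Nothing at hand accounts for either step.

The compounds shown leave open whether methoxy, a longer chain such as butoxy, an amine or a carboxylic acid at this same place would match ethoxy. They also leave open whether ethoxy would give a step of similar size on a compound without the nitro group, and whether nitro would matter without ethoxy.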